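Bromo for Trifluoromethyl in a Phenylethyl Urea Pair

The compounds below may be only part of what the source reports. "The series", "measured", "known", "first", "only" and "open" are said of these compounds alone.

Measured compounds:
compound 1, `CCc1ccccc1NC(=O)N[C@@H](C)c1ccccc1`, 100%
compound 2, `C[C@H](NC(=O)Nc1ccccc1C(F)(F)F)c1ccccc1`, 97%

Two ureas have been run in an ADME assay on the whole organism with Oryza sativa as the target, tested at 0.1 uM; a higher number here means a weaker effect of the compound at the concentration tested, a lower number a stronger effect. Compound 1 gives 100%, and compound 2 gives 97%. The single measured step, a number 3 percentage points lower from compound 1 to compound 2 (within the scatter), places the two numbers within the scatter of each other, so on the numbers shown compound 2 sits beside compound 1 rather than apart from it.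

Compound 3, `C[C@H](NC(=O)Nc1ccccc1Br)c1ccccc1`, is not yet measured. It differs from compound 2 in one place: bromo in place of trifluoromethyl on an aromatic carbon. Within the data shown here, the only step that bears on this change is the one from compound 1 to compound 2, which swapped a group on the same aromatic carbon and produced a change inside the scatter. Nothing measured here points to a shift beyond the scatter when a bromo replaces a trifluoromethyl at that carbon, so the expected step is a number 1 percentage points higher from compound 2 to compound 3 (within the scatter). On this basis compound 3 is estimated to give 98% in this assay, with an expected range from 90% to 100%.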

Compound 3, a percentage reported as activity, at one concentration (the size of the read-out at that concentration, not a potency): 101%
For compound 3 the middle estimate is 3 percentage points below the measured one, and the stated range ends below it.
By their numbers in this assay, from the lowest: compounds 2, 1 and 3 (each within the scatter of the next).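

In this assay the bromo gives a number 4 percentage points higher from compound 2 to compound 3 (within the scatter) and a number 1 percentage points higher from compound 1 to compound 3 (within the scatter) so ethyl, trifluoromethyl and bromo, all on the aromatic carbon ortho to a large group, now stand within the scatter of one another. The earlier pair offered a single step at this carbon, whereas the three compounds now give three steps, and none of them lies beyond the scatter. Exchanging the trifluoromethyl of 4 heavy atoms for the bromo of 1 heavy atom also leaves compound 2 and compound 3 unseparated by this read-out, although no evidence bears on why these numbers sit together. The compounds shown leave open whether any group on this carbon can produce a step beyond the scatter, for example an amine, a carboxylic acid, a methoxy group or a longer chain. They also leave open whether the bromo would behave the same way on another carbon of the ring, and whether a different concentration in this assay would separate these three compounds.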